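Cyclohexyl replaces 3-hydroxyphenyl on the shared core

The source may report more compounds than this note shows. Statements on the series, on what has been measured and on what is new or still open speak of the compounds shown alone.

In an ADME assay on THP-1 cells (Homo sapiens) for cytotoxicity, read by flow cytometry and propidium iodide staining, with a stated time of 48 h (a higher number here means that more compound is tolerated, a lower number that less compound is tolerated), compound 1 (`O=[N+]([O-])c1cc(C(F)(F)F)cc([N+](=O)[O-])c1Nc1ccc(O)cc1`) gives 40000 nM and compound 2 (`O=[N+]([O-])c1cc(C(F)(F)F)cc([N+](=O)[O-])c1Nc1cccc(O)c1`) gives 35000 nM, so the two stand level. Compound 3 (`O=[N+]([O-])c1cc(C(F)(F)F)cc([N+](=O)[O-])c1NC1CCCCC1`) has cyclohexyl in place of 3-hydroxyphenyl on a nitrogen on an aromatic ring. For the measured compounds named here, the only measured step, a 1.1-fold lower number from compound 1 to compound 2 (0.06 log units; within the scatter), exchanges one hydroxyphenyl for another, and no measured compound shows what replacing the aromatic ring does. It is a weak guide, so no step beyond the scatter is expected in this assay, with wide uncertainty. The expected change is a 1.4-fold lower number from compound 2 to compound 3 (0.15 log units; within the scatter). For compound 3 the estimated value is 25000 nM, with an expected range of 8000 nM to 70000 nM.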

Compound 3, half-maximal cytotoxic concentration: > 50000 nM
Compound 3 gave a limit, no number (the forecaster's own chance of this, stated with the estimate: 15%); at least 2.0-fold (0.30 log units) between middle value and limit.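

In this assay compound 3 gives no number, only a limit: the limit of > 50000 nM in this assay, at which 1 of the 3 values shown sits. For the compounds shown here, this is the first view of the aromatic ring being replaced on that nitrogen, and cyclohexyl shows no loss of tolerated concentration, with an at least 1.4-fold higher number from compound 2 to compound 3 (0.15 log units; that floor lies within the scatter) and an at least 1.2-fold higher number from compound 1 to compound 3 (0.09 log units; that floor lies within the scatter) as the two steps. Both floors lie within the scatter, so how far compound 3 truly stands from either hydroxyphenyl compound cannot be read.

On these data alone, the actual value of compound 3 remains open. So does whether an amine or a carboxylic acid on the cyclohexyl ring would change the number in this assay at all.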